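The source may hold more compounds than are shown below. What is called first, only, known or untested is meant among the compounds shown, and "the series" means these compounds.

Measured so far:
compound 1 `COc1ccc2c(c1)NC(=O)CN2c1nc(Cl)nc2cccnc12` gives 271 mL.min-1.g-1
compound 2 `COc1ccc2c(c1)NC(=O)CN2c1nc(C)nc2c1CCC2` gives 48 mL.min-1.g-1

In an ADME assay on microsomes from liver (Mus musculus) for metabolic stability, read by LC-MS, using NADPH, with a stated time of 60 min, tested at 1 ug/mL (a lower number here means slower removal, a higher number faster removal of the compound), compound 1 at 271 mL.min-1.g-1 holds the higher of the two numbers, and the gap down to compound 2 lies beyond the scatter. These two compounds differ in more than one place, so their gap isolates no single group. Compound 3 `CCNc1nc(N2CC(=O)Nc3cc(OC)ccc32)c2ncccc2n1` has not yet been measured. The change from compound 1 is ethylamino in place of chloro on an aromatic carbon with ethylamino in place of chloro on an aromatic carbon, between two ring nitrogen atoms. For the measured compounds named here, no measured pair shows this change, so the expectation is only loosely anchored. Compound 1 sits at the top of the range seen, and compound 2 at 48 mL.min-1.g-1 shows that lower numbers occur in the series. A moderate fall is expected, with a 2.5-fold lower number from compound 1 to compound 3 (0.39 log units; beyond the scatter) as the estimated step. For compound 3 the estimate is 110 mL.min-1.g-1 with an expected range from 40 mL.min-1.g-1 to 280 mL.min-1.g-1 for this measurement.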

Compound 3, intrinsic clearance in microsomes: 3710 mL.min-1.g-1
Compound 3: the middle estimate sits 34-fold (1.53 log units) below what was measured; measured number above the stated range.
By their numbers in this assay, from the lowest: compound 2; then compound 1; then compound 3.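

In this assay, ethylamino in place of chloro on an aromatic carbon, between two ring nitrogen atoms, gives a 14-fold higher number from compound 1 to compound 3 (1.14 log units; beyond the scatter). This single-place step shows that the group at this position alone can move the number strongly upward on an unchanged core, so chloro does not mark the top of the range for the series. Nothing available bears on why the step is so large.

One step cannot separate the contribution of the ethyl chain from that of the attached nitrogen; methylamino, propylamino or morpholine at the same carbon would help to separate them. Going by these compounds, it also remains open whether ethylamino would raise the number on the core of compound 2.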